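Aryl sulfide in place of nitrile: cytotoxicity outlook

The source may hold more compounds than are shown below. What is called first, only, known or untested is meant among the compounds shown, and "the series" means these compounds.

Compound 3 `Cc1cc(C#N)cn2c(CSCCc3ccccc3)cnc12` stands level with compound 1 `Cc1cc(N2CCCC2)cn2c(CSCCc3ccccc3)cnc12` and compound 2 `Cc1cc(-n2ccc3cccnc32)cn2c(CSCCc3ccccc3)cnc12` in an ADME assay on HEL cells (Homo sapiens) for cytotoxicity, with a stated time of 3 days; a lower number here means that less compound is tolerated, a higher number that more compound is tolerated. In this assay compound 1 gives 20 ug/mL, compound 2 gives 20 ug/mL and compound 3 gives 20 ug/mL. The exchanges made so far on this aromatic carbon, no change at the digits printed from compound 1 to compound 2 (within the scatter), no change at the digits printed from compound 1 to compound 3 (within the scatter) and no change at the digits printed from compound 2 to compound 3 (within the scatter), all remain within the scatter, even though the groups swapped differ widely in size and ring content. Compound 4 `Cc1cc(Sc2ccc(Cl)cc2)cn2c(CSCCc3ccccc3)cnc12` carries the change (4-chlorophenyl)sulfanyl in place of cyano on an aromatic carbon on the same aromatic carbon. Given three flat steps there, no move beyond the scatter is expected. The estimated step of no change at the digits printed from compound 3 to compound 4 (within the scatter) is accordingly flat. Compound 4 is expected to give 20 ug/mL, with a range of 10 ug/mL to 40 ug/mL.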

Compound 4, minimum cytotoxic concentration: 20 ug/mL
The estimate for compound 4 equals the measured number at the digits printed; the measured number falls inside the stated range.
By their numbers in this assay, from the lowest: compounds 1, 2, 3 and 4 (each within the scatter of the next).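

In this assay, (4-chlorophenyl)sulfanyl, the only group shown on this aromatic carbon with sulfur and chlorine, gives no change at the digits printed from compound 3 to compound 4 (within the scatter), alongside no change at the digits printed from compound 2 to compound 4 (within the scatter) and no change at the digits printed from compound 1 to compound 4 (within the scatter). The flat reading at this position therefore now extends to a chlorinated phenyl ring joined through sulfur, and all four groups read alike. No evidence bears on why this read-out stays flat. Open, from the compounds shown here alone, is whether a carboxylic acid or a primary amine on this carbon would leave the reading level.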